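Changing the Amide Aryl Group in a Weakly Active Series

The source may report more compounds than this note shows. Statements on the series, on what has been measured and on what is new or still open speak of the compounds shown alone.

Measured in a functional assay on HeLa cells (Homo sapiens) for antiproliferative activity, with a stated time of 24 h; a lower number here means a stronger inhibitor, a higher number a weaker inhibitor:
compound 1 `COc1ccccc1NC(=S)N1CCc2c(sc(NC(=O)c3ccccc3Cl)c2C(N)=O)C1`, which reaches only the limit > 50000 nM.
compound 2 `CSc1ccccc1NC(=S)N1CCc2c(sc(NC(=O)c3ccccc3Cl)c2C(N)=O)C1`, which gives 43600 nM.
compound 3 `NC(=O)c1c(NC(=O)c2ccccc2Cl)sc2c1CCN(C(=S)Nc1ccc(C(F)(F)F)cc1)C2`, which reaches only the limit > 50000 nM.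

Compound 3 therefore stands at the limit of this assay, and that limit is shared by another compound (the limit of > 50000 nM in this assay, at which 2 of the 3 values shown sit). The steps of an at least 1.1-fold lower number from compound 1 to compound 2 (0.05 log units; that floor lies within the scatter) and an at least 1.1-fold higher number from compound 2 to compound 3 (0.05 log units; that floor lies within the scatter) sit within the scatter, and the step that the two limits leave unreadable from compound 1 to compound 3 cannot be read at all.

Compound 4 `NC(=O)c1c(NC(=O)c2ccc(C(F)(F)F)cc2)sc2c1CCN(C(=S)Nc1ccc(C(F)(F)F)cc1)C2` differs from compound 3 by 4-(trifluoromethyl)phenyl in place of 2-chlorophenyl on a carbonyl carbon. All measured steps change the group on the amide-type nitrogen of the thiourea, not the carbonyl side, so none of them bears on this change. With nothing pointing to a gain, the step of a number no higher from compound 3 to compound 4 (the limit leaves the size open) is expected to be none beyond the scatter. Compound 4 is estimated at 50000 nM, within 15000 nM to 150000 nM, most likely again only a limit.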

Compound 4, half-maximal inhibitory concentration: > 50000 nM
Compound 4: only a limit was reported; the forecaster's own chance of this, stated with the estimate: 70%; the middle value lies on the limit itself.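

In this assay compound 4 gives > 50000 nM, which is a limit and not a number. Compound 3 also sits at a limit, so the step from compound 3 to compound 4 cannot be read. Going by these compounds, how 4-(trifluoromethyl)phenyl and 2-chlorophenyl on the carbonyl carbon truly compare stays open.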